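Replacing vinyl on the carbonyl carbon of compound 1

The source may report more compounds than this note shows. Statements on the series, on what has been measured and on what is new or still open speak of the compounds shown alone.

Compound 1 `C=CC(=O)N1CCSC1COc1ccccc1OC` serves as the reference point in a functional assay on the whole organism for inhibition, with Cavia porcellus as the target; on this read-out higher numbers stand for an effect only at larger amounts of compound and lower numbers for an effect already at smaller amounts. Within the data shown here, in that read-out, compound 1 gives 74 mg/kg, the higher of the two numbers so far. Compound 2 `O=C(O)CC(=O)N1CCSC1COc1ccccc1O` gives 25 mg/kg, a lower number by a margin beyond the usual scatter, although it differs from compound 1 in more than one place.

The next entry is compound 3 `CCOC(=O)C(C)(C)C(=O)N1CCSC1COc1ccccc1OC`, which carries 1-(ethoxycarbonyl)-1-methylethyl in place of vinyl on a carbonyl carbon. Among the measured compounds shown here, no measured pair isolates a change at this carbonyl carbon, so the direction rests on thin evidence. For the measured compounds named here, the sole guide is that compound 1 at 74 mg/kg stands at the top of a very short range, which leaves a move toward lower numbers somewhat more likely than a move upward. In this assay, the expected change is modest, and the estimated step is a 1.6-fold lower number from compound 1 to compound 3 (0.22 log units; within the scatter), which may not clear the scatter. For compound 3, the estimated value is 45 mg/kg, with an expected range of 15 mg/kg to 130 mg/kg.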

Compound 3, dose for half-maximal effect: 61 mg/kg
For compound 3 the middle estimate is 1.4-fold (0.13 log units) below the measured one; the measured number falls inside the stated range.
By their numbers in this assay, from the lowest: compound 2; then compounds 3 and 1 (each within the scatter of the next).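

In this assay, among these compounds, the step for 1-(ethoxycarbonyl)-1-methylethyl in place of vinyl is a 1.2-fold lower number from compound 1 to compound 3 (0.08 log units; within the scatter), the first step that isolates this carbonyl carbon, whose other neighbour is the amide-type nitrogen in a ring. Within the scatter, the read-out does not separate the two groups, even though the entering group has 8 heavy atoms and 2 hydrogen-bond acceptors and vinyl has 2 heavy atoms and 0 hydrogen-bond acceptors. No measured property bears on why the two compounds read alike.

As far as these compounds go, whether a carboxylic acid or an amine in place of vinyl, on the otherwise unchanged core of compound 1, would shift the number beyond the scatter remains open. Compound 2 does not settle this, since it differs from compound 1 in more than one place and its number cannot be assigned to the group on the carbonyl carbon alone.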